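Carbamate tail variation on a tetrazole ghrelin receptor series

A few compounds are considered here, and "the series" means these few. Any claim that something is new, unique, unknown or untested is made for them only; others in the source may bear on it.

Measured compounds:
compound 1 `CC(C)(N)C(=O)N[C@H](COCc1ccccc1)c1nnnn1CCOC(=O)NCCCCCO` — 14.6 nM
compound 2 `CC(=O)NCCCCNC(=O)OCCn1nnnc1[C@@H](COCc1ccccc1)NC(=O)C(C)(C)N` — 82.5 nM

For the measured compounds named here, in a functional assay on H4 cells with growth hormone secretagogue receptor type 1 (Homo sapiens) as the target, read by FLIPR (on this read-out higher numbers stand for an effect only at larger amounts of compound and lower numbers for an effect already at smaller amounts), compound 2 gives 82.5 nM, the higher of the two numbers measured so far; compound 1 gives 14.6 nM. Going by the values given here, the one step between them, a 5.7-fold higher number from compound 1 to compound 2 (0.75 log units; beyond the scatter), shows that the end of the carbamate chain shifts the read-out by a modest but real amount. Compound 3 `CC(C)(N)C(=O)N[C@H](COCc1ccccc1)c1nnnn1CCOC(=O)NC[C@H]1CCCO1` has not been measured. It differs from compound 2 by oxolan-2-yl in place of 3-acetamidopropyl on a saturated chain carbon bound to an amide-type nitrogen, so the acetamidopropyl chain is gone and a ring bearing one acceptor and no donor takes its place. Among the compounds with values here, only the step from compound 1 to compound 2 bears on this region, and it shows that changes there can move this assay beyond the scatter. Compound 3 is therefore expected to land near the two measured numbers, with its step estimated as a 2.1-fold lower number from compound 2 to compound 3 (0.31 log units; beyond the scatter), giving an estimate of 40 nM within 10 nM to 200 nM.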

Compound 3, half-maximal effective concentration: 9.5 nM
Estimate against measurement, compound 3: 4.2-fold (0.62 log units) above, and the stated range ends above it.
By their numbers in this assay, from the lowest: compounds 3 and 1 (each within the scatter of the next); then compound 2.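

In this assay, oxolan-2-yl in place of 3-acetamidopropyl on the saturated chain carbon bound to the amide-type nitrogen gives an 8.7-fold lower number from compound 2 to compound 3 (0.94 log units; beyond the scatter), so the higher number seen with the acetamido-bearing chain does not extend to every change at this place. Oxolan-2-yl in place of 4-hydroxybutyl on the same carbon gives a 1.5-fold lower number from compound 1 to compound 3 (0.19 log units; within the scatter), which shows that neither an open chain nor its terminal hydroxyl is required here for a number in the range of compound 1. Nothing available explains these shifts.

On these data alone, it remains open whether a terminal amine, a carboxylic acid or a longer chain would keep the number at this level. Also open, as far as these compounds go, are how a six-membered oxane ring would compare and what the opposite configuration at the oxolan-2-yl stereocentre would do.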